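A few compounds are considered here, and "the series" means these few. Any claim that something is new, unique, unknown or untested is made for them only; others in the source may bear on it.

Among the compounds with values here, compound 1 `CC(O)C1=CC(=O)c2ccccc2C1=O` gives 6400 nM in a functional assay on WHCO1 cells (Homo sapiens) for cytotoxicity, read by MTT assay, with a stated time of 24 h (a higher number here means a weaker inhibitor, a lower number a stronger inhibitor), the highest of the two numbers so far. Compound 2 `O=C1C=C([C@@H](O)c2ccccc2)C(=O)c2ccccc21` gives 3800 nM in this assay, a difference from compound 1 that lies within the scatter. Compound 3 `O=C1C=C(C(O)c2ccc(Cl)cc2)C(=O)c2ccccc21` differs from compound 1 by 4-chlorophenyl in place of methyl on a saturated chain carbon bound to a double-bonded ring carbon and an oxygen on a saturated carbon. Within the data shown here, no measured pair shows this exact change on its own. Because compound 2 gives 3800 nM, a value within the scatter of compound 1, no step beyond the scatter is expected from the change. The expected step is a 1.8-fold lower number from compound 1 to compound 3 (0.26 log units; within the scatter). Compound 3 is estimated at 3500 nM, with a range from 1500 nM to 8000 nM.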

Compound 3, half-maximal inhibitory concentration: 3000 nM
The estimate for compound 3 lay 1.2-fold (0.07 log units) above the measured number, and the stated range covers the measured number.
By their numbers in this assay, from the lowest: compounds 3, 2 and 1 (each within the scatter of the next, the first and the last beyond it).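

With 4-chlorophenyl in place of methyl on this saturated chain carbon, this assay shows a 2.1-fold lower number from compound 1 to compound 3 (0.33 log units; beyond the scatter) as a modest step. Within the data shown here, compound 2 had stayed within the scatter of compound 1, so this is the first change at this position to pass beyond it. No evidence bears on why the number falls, and the step rests on this one pair. The compounds shown leave open how a longer chain, an amine or a carboxylic acid at this position would compare with methyl and 4-chlorophenyl.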